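Lengthening the amide chain and toxicity toward CEM-SS cells

The compounds below may be only part of what the source reports. "The series", "measured", "known", "first", "only" and "open" are said of these compounds alone.

Among the compounds with values here, compound 3 `CCCC(=O)OCSc1ccccc1C(=O)NCCCCCC(N)=O` is the only one of three compounds to give a number in an ADME assay on CEM-SS cells (Homo sapiens) for cytotoxicity, read by XTT assay, with a stated time of 6 days; on this read-out lower numbers stand for higher toxicity in this test and higher numbers for lower toxicity in this test: compound 3 gives 16.3 uM. Compound 1 `CCCC(=O)OCSc1ccccc1C(=O)NCCC(N)=O` reaches only a limit of the test, > 100 uM. Compound 2 `CCCC(=O)OCSc1ccccc1C(=O)NCC(N)=O` likewise gives the limit > 100 uM. The steps toward compound 3 are therefore an at least 6.1-fold lower number from compound 1 to compound 3 (0.78 log units; beyond the scatter) and an at least 6.1-fold lower number from compound 2 to compound 3 (0.78 log units; beyond the scatter); both rest on (the limit of > 100 uM in this assay, at which 2 of the 3 values shown sit). Compound 4 `CCCC(=O)OCSc1ccccc1C(=O)NCCCCCCNC(C)=O` differs from compound 3 by acetamidomethyl in place of carbamoyl on a saturated chain carbon, five bonds along the chain from an amide-type nitrogen. Both measured steps put a longer carbamoyl-bearing group in place of carbamoyl and lower the number; the change to compound 4 also adds length but exchanges the end group, so only a small shift toward lower numbers is expected. The estimate for compound 4 is 12 uM, spanning 4 uM to 40 uM, a step of a 1.4-fold lower number from compound 3 to compound 4 (0.13 log units; within the scatter).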

Compound 4, half-maximal toxic concentration: 8 uM
Compound 4: the middle estimate sits 1.5-fold (0.18 log units) above what was measured, and the stated range covers the measured number.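

In this assay, exchanging the end group at this place still moves the number, with a 2.0-fold lower number from compound 3 to compound 4 (0.31 log units; beyond the scatter), although carbamoyl and acetamidomethyl carry the same counts of hydrogen-bond donors and acceptors. The gap to the shorter compounds widens to an at least 12-fold lower number from compound 2 to compound 4 (1.09 log units; beyond the scatter) and an at least 12-fold lower number from compound 1 to compound 4 (1.09 log units; beyond the scatter). Both of these wider steps rest on a limit of the test: the limit of > 100 uM in this assay, at which 2 of the 4 values shown sit.

Whether the added carbons or the acetamido end accounts for the step from carbamoyl stays open. A longer chain ending in carbamoyl, or a chain ending in an amine or a carboxylic acid, would help separate the two.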